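The compounds below may be only part of what the source reports. "The series", "measured", "known", "first", "only" and "open" are said of these compounds alone.

Measured compounds:
compound 1 `Clc1cccc(Cl)c1Cc1nnc(Nc2ccc(COCc3ccoc3)cc2)o1`: 21000 nM
compound 2 `Clc1cccc(Cl)c1Cc1nnc(Nc2ccc(COCc3cccnc3)cc2)o1`: 81000 nM
compound 3 `Clc1cccc(Cl)c1Cc1nnc(Nc2ccc(COCc3ccsc3)cc2)o1`: reported only as a limit of the test, > 100000 nM

These values come from an ADME assay on MT2 cells (Homo sapiens) for cytotoxicity, read by MTT assay; on this read-out lower numbers stand for higher toxicity in this test and higher numbers for lower toxicity in this test. Compound 3 stands at the upper edge of the numbers shown, since for compound 3 the result is a limit of > 100000 nM in this assay, at which 1 of the 3 values shown sits, and not a number. The steps onto compound 3 are an at least 4.7-fold higher number from compound 1 to compound 3 (0.67 log units; beyond the scatter) and an at least 1.2-fold higher number from compound 2 to compound 3 (0.09 log units; that floor lies within the scatter). The not yet measured compound 4 `Clc1cccc(Cl)c1Cc1nnc(Nc2ccc(COCc3ccccc3)cc2)o1` differs from compound 3 in one place: phenyl in place of thiophen-3-yl on a saturated chain carbon bound to an oxygen on a saturated carbon. For the measured compounds named here, no measured step moves from thiophen-3-yl to phenyl, so the step to compound 4 has no direct precedent; the three measured compounds vary the same group, and the phenyl case remains untested. The expectation is therefore a step of a number no higher from compound 3 to compound 4 (the limit leaves the size open), that is, none beyond the scatter, with a fair chance that compound 4 again returns only a limit. Compound 4 is estimated at 100000 nM, within 40000 nM to 250000 nM.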

Compound 4, half-maximal cytotoxic concentration: 84000 nM
Compound 4: middle estimate off by 1.2-fold (0.08 log units), on the high side, within the range that was stated.
By their numbers in this assay, from the lowest: compound 1; then compounds 2 and 4 (each within the scatter of the next). At a limit, above all of these: compound 3.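

In this assay, a ring of carbon only at this place, on a saturated chain carbon bound to an oxygen on a saturated carbon, gives a 1.0-fold higher number from compound 2 to compound 4 (0.02 log units; within the scatter), so phenyl and pyridin-3-yl are not told apart here. Furan-3-yl now stands apart from a third ring, with a 4.0-fold higher number from compound 1 to compound 4 (0.60 log units; beyond the scatter), and compound 1 has the lowest number of the four compounds. The remaining step is an at least 1.1-fold lower number from compound 3 to compound 4 (0.07 log units; that floor lies within the scatter), and its size cannot be read, as it starts from a limit of the test: the limit of > 100000 nM in this assay, at which 1 of the 4 values shown sits.

On these data alone, how far compound 3 truly lies from compound 4 remains open. So does whether the low number of compound 1 is particular to furan-3-yl, since furan-2-yl, cyclohexyl, an amine or a carboxylic acid at this place are not among the compounds shown.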